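Turning a Z Double Bond to E in Compound 4

The source may report more compounds than this note shows. Statements on the series, on what has been measured and on what is new or still open speak of the compounds shown alone.

Compound 3 `C/C(C(=O)NC1CC1)=C(\C)c1ccccc1` gives 400 mg/kg in a toxicity assay on the whole organism (strain Icem-CET (SPF Caw)) for cytotoxicity, with Mus musculus as the target (on this read-out lower numbers stand for an effect already at smaller amounts and higher numbers for an effect only at larger amounts of compound), the highest of the three numbers measured. Nearest to it stands compound 1 `COc1ccc(/C(C)=C(/C)C(=O)NC2CC2)cc1`, which gives 300 mg/kg in this assay, the step of a 1.3-fold higher number from compound 1 to compound 3 (0.12 log units; within the scatter) lying within the scatter. Furthest away stands compound 2 `C/C(C(=O)NC1CC1)=C(/C)c1ccc(Br)cc1`, which gives 100 mg/kg in this assay, a number beyond the scatter of that of compound 3.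

Compound 4 `C/C(C(=O)NC1CC1)=C(/C)c1ccccc1` differs from compound 3 in one respect: the two compounds have the same atoms and bonds and differ only in configuration as drawn: 1 of 1 stereo elements differ; a double bond is drawn Z in compound 3 and E in compound 4. Going by the values given here, no measured step bears on this change. Among the compounds with values here, the single step between compounds that differ in one place concerns hydrogen in place of methoxy on an aromatic carbon, and the pair formed by compound 2 and compound 3 differs in more than one place, so neither says anything about a double bond drawn Z or E. In the absence of any guide the writer expects no step beyond the scatter, namely no change at the digits printed from compound 3 to compound 4 (within the scatter). Compound 4 is therefore estimated at 400 mg/kg, with a range from 150 mg/kg to 1000 mg/kg.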

Compound 4, dose for half-maximal effect: 100 mg/kg
Compound 4: the middle estimate sits 4.0-fold (0.60 log units) above what was measured; the measured number lies below the stated range.
By their numbers in this assay, from the lowest: compounds 2 and 4 (each within the scatter of the next); then compounds 1 and 3 (each within the scatter of the next).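

In this assay, the double bond is the only single change shown that moves the number beyond the scatter, with a 4.0-fold lower number from compound 3 to compound 4 (0.60 log units; beyond the scatter). The change at the aromatic carbon looks different: the step with hydrogen in place of bromo gives no change at the digits printed from compound 2 to compound 4 (within the scatter), and the step with hydrogen in place of methoxy, a 1.3-fold higher number from compound 1 to compound 3 (0.12 log units; within the scatter), also stays within the scatter. The step of the first pair can be assigned to the drawn configuration of the double bond alone because nothing else separates the two compounds: the fact that compounds 3 and 4 differ only in the configuration as drawn

The compounds shown leave open whether the same step from Z to E would appear with bromo or methoxy on the aromatic carbon. They also leave open whether an amine or a carboxylic acid at that carbon would move the number in either configuration.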